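Swapping the alkyne aryl cap on a phenoxyacetic acid core

A few compounds are considered here, and "the series" means these few. Any claim that something is new, unique, unknown or untested is made for them only; others in the source may bear on it.

Measured compounds:
Compound 1 `Cc1ncccc1C#Cc1cc(Cl)ccc1OCC(=O)O` — 143 nM
Compound 2 `CC(C)S(=O)(=O)c1ccc(Cl)c(C#Cc2cc(Cl)ccc2OCC(=O)O)c1` — 2.9 nM
Compound 3 `COCc1ccc(C#Cc2cc(Cl)ccc2OCC(=O)O)c(F)c1` — 22 nM

Three compounds share a core and were tested in an assay on CHO cells for displacement of a labelled ligand from prostaglandin D2 receptor 2 (Homo sapiens), read by scintillation counting; a lower number here means a stronger inhibitor, a higher number a weaker inhibitor. Compound 1 gives 143 nM, the highest number of the three. Its nearest neighbour is compound 3, with 22 nM, a gap beyond the scatter, and furthest from it is compound 2, with 2.9 nM, a gap that is also beyond the scatter. So compound 1 stands as the weakest inhibitor among the measured set.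

Compound 4 `O=C(O)COc1ccc(Cl)cc1C#Cc1ccc(Cl)s1` has not yet been measured. It differs from compound 1 by 5-chlorothiophen-2-yl in place of 2-methylpyridin-3-yl on a triple-bonded carbon. Within the data shown here, no pair of measured compounds differs by this same change, so there is no directly comparable step; the two other aryl caps in compounds 2 and 3 both sit at lower numbers than compound 1, which suggests that the cap on the triple-bonded carbon can move the number considerably. On that basis the step of a 3.2-fold lower number from compound 1 to compound 4 (0.50 log units; beyond the scatter) in this assay is expected to be moderate and downward, though a result within the scatter of compound 1 would not be surprising. Compound 4 is estimated at 45 nM, with a range from 12 nM to 170 nM.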

Compound 4, inhibition constant: 183 nM
Beside the measured number, compound 4's estimate is 4.1-fold (0.61 log units) below it; the whole stated range lies below it.
By their numbers in this assay, from the lowest: compound 2; then compound 3; then compounds 1 and 4 (each within the scatter of the next).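

In this assay the step of a 1.3-fold higher number from compound 1 to compound 4 (0.11 log units; within the scatter) shows that 5-chlorothiophen-2-yl in place of 2-methylpyridin-3-yl on a triple-bonded carbon leaves the number within the scatter. Among these compounds, the earlier compounds showed only that the group in this place can carry a much lower number, as compound 3 at 22 nM and compound 2 at 2.9 nM do. This step adds that changing the ring from six-membered to five-membered, with a different hetero atom, does not by itself reach those numbers.

Going by these compounds, it remains open which part of the caps in compounds 2 and 3 goes with their lower numbers. On these data alone, it is also open whether a thiophene cap carrying an amine or a methyl in place of the chlorine would stay level with compounds 1 and 4. Nothing measured here explains the result.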